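Methyl in Place of Fluoro: Expected Solubility of Compound 4

This account rests on a few compounds, and the source may have more. Where it says the series, first, only, none or still open, it means among the compounds named here.

Of the compounds shown here, three built on one shared core have been measured in a physicochemical assay for solubility, read by HPLC, measured as thermodynamic solubility, with a stated time of 4 h, at pH 6.8; a lower number here means a less soluble compound, a higher number a more soluble compound. Compound 1 `Cn1c(COc2cccc(C(=O)O)c2)nc2ccc(Oc3ncccc3Cl)cc21` gives 15 ug/mL. Compound 2 `Cc1cc(F)cnc1Oc1ccc2nc(COc3cccc(C(=O)O)c3)n(C)c2c1` gives 14 ug/mL. Compound 3 `Cn1c(COc2cccc(C(=O)O)c2)nc2ccc(Oc3ncc(Cl)cc3F)cc21` gives 10 ug/mL, the lowest of the three numbers, although a 1.5-fold lower number from compound 1 to compound 3 (0.18 log units; within the scatter) and a 1.4-fold lower number from compound 2 to compound 3 (0.15 log units; within the scatter) both sit within the scatter, as does a 1.1-fold lower number from compound 1 to compound 2 (0.03 log units; within the scatter). Compound 4 `Cc1cc(Cl)cnc1Oc1ccc2nc(COc3cccc(C(=O)O)c3)n(C)c2c1` has not yet been measured in this assay. It differs from compound 3 by methyl in place of fluoro on an aromatic carbon. The measured step that bears most closely on this change is a 1.4-fold lower number from compound 2 to compound 3 (0.15 log units; within the scatter), in which 5-fluoro-3-methylpyridin-2-yl gives way to 5-chloro-3-fluoropyridin-2-yl, so that compound 2 shares the methyl with compound 4 while compound 3 shares the chloro with it. Every step among the measured compounds stays within the scatter, so no move beyond the scatter is expected in this assay, a 1.2-fold higher number from compound 3 to compound 4 (0.08 log units; within the scatter). Compound 4 is therefore estimated at 12 ug/mL, with a range from 6 ug/mL to 24 ug/mL.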

Compound 4, solubility: 3.9 ug/mL
Compound 4: middle estimate off by 3.1-fold (0.49 log units), on the high side, and the stated range ends above it.
By their numbers in this assay, from the lowest: compound 4; then compounds 3, 2 and 1 (each within the scatter of the next).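

In this assay, going by these compounds alone, methyl in place of fluoro on an aromatic carbon, ortho to a large group and two atoms from the ring nitrogen, gives a 2.6-fold lower number from compound 3 to compound 4 (0.41 log units; beyond the scatter) and so moves the number beyond the scatter, which no earlier step had done. Within the data shown here, the other two steps into compound 4 also pass the scatter: chloro in place of fluoro gives a 3.6-fold lower number from compound 2 to compound 4 (0.56 log units; beyond the scatter) with the methyl kept, and 5-chloro-3-methylpyridin-2-yl in place of 3-chloropyridin-2-yl gives a 3.8-fold lower number from compound 1 to compound 4 (0.59 log units; beyond the scatter) on the same oxygen, so the lowest number belongs to the only group here that carries both methyl and chloro. Nothing shown gives a reason for these drops.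

The compounds shown leave open whether the fall belongs to methyl itself or to its pairing with chloro. They also leave open what an ethyl chain or an amine would give on that aromatic carbon.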